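From compound 2 to compound 3: hydroxy to hydroxymethyl

The source may hold more compounds than are shown below. What is called first, only, known or untested is meant among the compounds shown, and "the series" means these compounds.

In an ADME assay on HepG2 cells (Homo sapiens) for cytotoxicity, read by luminescence, with a stated time of 72 h (on this read-out lower numbers stand for an effect already at smaller amounts and higher numbers for an effect only at larger amounts of compound), compound 1 (`CCOC(=O)c1c(-c2cccc(-c3ccccc3)c2)[nH]c2cc(OC)ccc2c1=O`) gives > 21500 nM as a limit of the assay and not a number. Compound 2 (`CCOC(=O)c1c(-c2cccc(O)c2)[nH]c2cc(OC)ccc2c1=O`) gives > 21500 nM as a limit too, so it has no readable place on the scale. Compound 3 (`CCOC(=O)c1c(-c2cccc(CO)c2)[nH]c2cc(OC)ccc2c1=O`) differs from compound 2 by hydroxymethyl in place of hydroxy on an aromatic carbon (hydroxymethyl in place of hydroxy on an aromatic carbon, meta to a large group). For the measured compounds named here, the only measured step that bears on it is a step that the two limits leave unreadable from compound 1 to compound 2 and it offers no size to carry over. What the data show is the limit of > 21500 nM in this assay, at which 2 of the 2 values shown sit, and nothing more. No step beyond the scatter is therefore expected in this assay and no direction either. For compound 3 the estimated value is 30000 nM with an expected range from 15000 nM to 60000 nM and a limit is the most likely report. That estimate means a step that the limit leaves unreadable from compound 2 to compound 3 as the expected step.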

Compound 3, half-maximal effective concentration: > 21500 nM
Compound 3 gave a limit, no number; the forecaster's own chance of this, stated with the estimate: 85%; the middle value does not contradict the limit.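

In this assay no new step can be read among compound 1, compound 2 and compound 3, each reported only as a limit: the limit of > 21500 nM in this assay, at which 3 of the 3 values shown sit.

The compounds shown leave open whether phenyl, hydroxy and hydroxymethyl differ at all in this read-out, and at what concentration any of the three would show an effect.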